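The source may hold more compounds than are shown below. What is called first, only, known or untested is meant among the compounds shown, and "the series" means these compounds.

Of the compounds shown here, two on a shared core have been tested so far, compound 1 (`Cc1noc(-c2nc(C)c3c(c2N)C(=O)N(Cc2ccc(OC(F)(F)F)cc2)C3=O)n1`) and compound 2 (`Cc1noc(-c2nc(C)c3c(c2N)C(=O)N(Cc2ccccc2Cl)C3=O)n1`). In a physicochemical assay for solubility, using the shake flask method, in simulated intestinal fluid, measured as kinetic solubility, with a stated time of 2 h, at 25 degrees C, at pH 6.5 (a higher number here means a more soluble compound, a lower number a less soluble compound), compound 1 gives < 5000 nM as a limit of the assay and not a number. Compound 2 gives < 5000 nM as a limit too. Compound 2 therefore has no number of its own, and the pair stands together on the limit of < 5000 nM in this assay, at which 2 of the 2 values shown sit, with nothing to set one apart from the other.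

The next compound is compound 3 (`Cc1noc(-c2nc(C)c3c(c2N)C(=O)N(Cc2ccc(S(C)(=O)=O)cc2)C3=O)n1`). It carries 4-(methylsulfonyl)phenyl in place of 2-chlorophenyl on a saturated chain carbon bound to an amide-type nitrogen in a ring. Going by the values given here, no measured step between compounds differing in one place is available to size this change. With compound 2 known only as < 5000 nM from a limit, no step beyond the scatter is expected in this assay in either direction. The expected step is a step that the limit leaves unreadable from compound 2 to compound 3 and it should be read loosely. A report of only a limit would be no surprise for compound 3. Compound 3 is estimated at 3000 nM (expected range 800 nM to 9000 nM).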

Compound 3, solubility: < 5000 nM
Compound 3 gave a limit, no number; the forecaster's own chance of this, stated with the estimate: 65%; the middle value lies beyond the limit too.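

In this assay compound 3 gives < 5000 nM as a limit of the assay and not a number. Neither the step from compound 2 to compound 3 nor the step from compound 1 to compound 3 can be read. The compounds shown leave open whether any one of the three differs from the others in this assay at all.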